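The source may hold more compounds than are shown below. What is called first, only, known or untested is meant among the compounds shown, and "the series" means these compounds.

Working notes on the series. The shared core is seen in compound 1 `CCCCOc1ccc(-c2c(C)[nH]c(=O)n2C)cc1`, which in a functional assay on brain (Rattus norvegicus, strain Wistar) for inhibition (a higher number here means a weaker inhibitor, a lower number a stronger inhibitor), gives 5100 nM. Compound 2 `CCCCc1ccc(-c2c(C)[nH]c(=O)n2Cc2ccccc2)cc1` gives 12400 nM in this assay. Within the data shown here, of the two numbers so far, compound 1 holds the lowest, with compound 2 a step away that lies beyond the scatter. The two measured compounds differ in more than one place, so nothing ties that gap to one change.

Compound 3 `Cc1[nH]c(=O)n(C)c1-c1ccc(C2CCCCC2)cc1` has not yet been measured in this assay. It differs from compound 1 in one place: cyclohexyl in place of butoxy on an aromatic carbon. Among the measured compounds shown here, no measured pair in the set isolates this change, so there is no direct precedent for its size. The expected step is a 1.4-fold higher number from compound 1 to compound 3 (0.14 log units; within the scatter), which is read as either no change beyond the scatter or a small move toward a weaker inhibitor. Compound 3 is therefore expected to give about 7000 nM in this assay, with a range from 2500 nM to 20000 nM. For the measured compounds named here, the estimate rests only on compound 1 and its single measured number.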

Compound 3, half-maximal inhibitory concentration: 10000 nM
Beside the measured number, compound 3's estimate is 1.4-fold (0.15 log units) below it; the range from low to high includes it.
By their numbers in this assay, from the lowest: compounds 1, 3 and 2 (each within the scatter of the next, the first and the last beyond it).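

In this assay, among these compounds, the one pair that differs in a single place reads a 2.0-fold higher number from compound 1 to compound 3 (0.29 log units; within the scatter), for cyclohexyl in place of butoxy on an aromatic carbon para to a group of 8 heavy atoms. This position therefore accepts an open chain bearing a hydrogen-bond acceptor or a carbon-only six-membered non-aromatic ring with no step beyond the scatter, so this exchange does not separate the two groups in this assay. Nothing available bears on why the step has this size, or on how the loss of the oxygen and the gain of the ring each contribute to it.

The compounds shown leave open whether the oxygen and the ring each have any effect of their own, which a pair with cyclohexyloxy or a plain pentyl chain on the same aromatic carbon could begin to separate. They also leave open whether this position stays this flat with a very different group there, such as an amine or a carboxylic acid, and whether any such result would carry over to the benzyl-bearing scaffold of compound 2.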